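Benzyl-piperidine amides of a hindered phenol: nitro for fluorine

This account rests on a few compounds, and the source may have more. Where it says the series, first, only, none or still open, it means among the compounds named here.

Measured so far in an assay on isolated protein for inhibition of Amine oxidase [flavin-containing] A (Homo sapiens), read by fluorescence, with stated times of 15 min and 20 min; on this read-out higher numbers stand for weaker inhibition and lower numbers for stronger inhibition:
- compound 1, `CC(C)(C)c1cc(C(=O)NCCC2CCN(Cc3ccccc3)CC2)cc(C(C)(C)C)c1O`: 109000 nM
- compound 2, `CC(C)(C)c1cc(/C=C/C(=O)NC2CCN(Cc3ccccc3)CC2)cc(C(C)(C)C)c1O`: 42500 nM
- compound 3, `CC(C)(C)c1cc(/C=C/C(=O)NCCC2CCN(Cc3ccccc3F)CC2)cc(C(C)(C)C)c1O`: 60200 nM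

Compound 3 sits between the other two numbers; its gap to compound 2 and its gap to compound 1 both lie within the scatter, so the three compounds cannot be told apart on this assay. Within the data shown here, no single-change pair among them is recorded, and nothing here connects the phenyl substituent to the read-out.

Compound 4, `CC(C)(C)c1cc(/C=C/C(=O)NCCC2CCN(Cc3cccc([N+](=O)[O-])c3)CC2)cc(C(C)(C)C)c1O`, differs from compound 3 only by 3-nitrophenyl in place of 2-fluorophenyl on a saturated chain carbon bound to an amine nitrogen in a ring. Among the measured compounds shown here, with no comparable step known, the expectation is for compound 4 to stay close to compound 3, with the step of a 1.0-fold lower number from compound 3 to compound 4 (0.00 log units; within the scatter) in this assay amounting to nothing beyond the scatter. The estimate for compound 4 is 60000 nM, ranging from 20000 nM to 180000 nM.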

Compound 4, half-maximal inhibitory concentration: 70900 nM
For compound 4 the middle estimate is 1.2-fold (0.07 log units) below the measured one; the measured number falls inside the stated range.
By their numbers in this assay, from the lowest: compounds 2, 3, 4 and 1 (each within the scatter of the next, the first and the last beyond it).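

In this assay, 3-nitrophenyl in place of 2-fluorophenyl on a saturated chain carbon bound to an amine nitrogen in a ring gives a 1.2-fold higher number from compound 3 to compound 4 (0.07 log units; within the scatter). This first single-change pair shows no difference that the assay can resolve, although the substituent and its place on the phenyl ring both change. No supporting data bear on this result.

Still open, from the compounds shown here alone, is whether the substituent and its place each have no effect, or whether the two effects offset. A carboxylic acid or an amine in place of the nitro group remains an open test of this position.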